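The source may report more compounds than this note shows. Statements on the series, on what has been measured and on what is new or still open speak of the compounds shown alone.

Three compounds of one series, all sharing the core of compound 1, have been measured in a physicochemical assay for lipophilicity, measured as octanol-water partition; a higher number here means a more lipophilic compound, a lower number a more polar compound. Compound 1 `O=C(COc1cccc2ccccc12)N/N=C/c1ccc(O)cc1` gives 3.73, the highest of the three numbers. Compound 2 `C/C(=N\NC(=O)COc1cccc2ccccc12)c1ccc(C#N)cc1Br` gives 3.61, within the scatter of compound 1. Compound 3 `COc1cc(/C=N/NC(=O)COc2cccc3ccccc23)cc(OC)c1OC` gives 3.26, beyond the scatter below compound 1. Compound 4 `O=C(COc1cccc2ccccc12)N/N=C/c1ccccc1Cl` has not yet been measured in this assay. It differs from compound 1 in one place: 2-chlorophenyl in place of 4-hydroxyphenyl on a carbon with a double bond to nitrogen. Among the measured compounds shown here, no single-change step between measured compounds is available to calibrate this exchange, so the expectation rests on compound 1 alone. For this exchange a sizeable step upward is expected, namely a number 1.07 log units higher from compound 1 to compound 4 (beyond the scatter). Compound 4 is therefore expected to give about 4.8, with a range from 4.3 to 5.3.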

Compound 4, partition coefficient: 4.54
For compound 4 the middle estimate is 0.26 log units above the measured one; the measured number falls inside the stated range.
By their numbers in this assay, from the lowest: compound 3; then compounds 2 and 1 (each within the scatter of the next); then compound 4.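

In this assay, among the compounds shown here, the exchange of 4-hydroxyphenyl for 2-chlorophenyl on a carbon with a double bond to nitrogen gives the first single-change step, a number 0.81 log units higher from compound 1 to compound 4 (beyond the scatter), showing that the number depends on the group held at this place. The exchange also removes the hydrogen-bond donor and acceptor counted on the leaving group and brings in chlorine. Nothing available explains the size of this step.

Going by these compounds, how much of the step belongs to the loss of hydroxyl and how much to the gain of chlorine stays open. Unsubstituted phenyl at this place would separate the two, and an amine or a carboxylic acid on the ring would extend the comparison.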